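This account rests on a few compounds, and the source may have more. Where it says the series, first, only, none or still open, it means among the compounds named here.

Among the compounds with values here, in an ADME assay on microsomes from liver (Mus musculus), read by LC-MS, using NADPH, with a stated time of 30 min, tested at 1 uM (on this read-out lower numbers stand for a less stable compound and higher numbers for a more stable compound), compound 3 `C[C@H](Nc1nc(N)nc(N)c1C#N)c1c(-c2ccccc2)c(=O)n2cc(F)ccc2c1-c1ccccc1` gives 13%, the lowest of the three numbers measured so far: compound 1 `C[C@H](Nc1nc(N)nc(N)c1C#N)c1cc2ccc(F)cn2c(=O)c1-c1ccccc1` gives 42% and compound 2 `Cc1c([C@H](C)Nc2nc(N)nc(N)c2C#N)c(-c2ccccc2)c(=O)n2cc(F)ccc12` gives 85%. The measured steps all concern one group on the shared core: a number 43 percentage points higher from compound 1 to compound 2 (beyond the scatter), a number 29 percentage points lower from compound 1 to compound 3 (beyond the scatter) and a number 72 percentage points lower from compound 2 to compound 3 (beyond the scatter). Compound 4 `COc1ccc(-c2c([C@H](C)Nc3nc(N)nc(N)c3C#N)c(-c3ccccc3)c(=O)n3cc(F)ccc23)cc1` differs from compound 3 by methoxy in place of hydrogen on an aromatic carbon. Within the data shown here, none of the measured steps changes a group on that phenyl, so none bears directly on this change, and compound 3 at 13% leaves little room for a further fall. A step no larger than the usual scatter in this assay is therefore expected, a number 3 percentage points lower from compound 3 to compound 4 (within the scatter). Compound 4 is estimated to give 10% in this assay, within 3% to 25%.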

Compound 4, percent of the compound remaining: 82%
The estimate for compound 4 lay 72 percentage points below the measured number; the measured number lies above the stated range.
By their numbers in this assay, from the lowest: compound 3; then compound 1; then compounds 4 and 2 (each within the scatter of the next).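

A phenyl at this position does not by itself fix a low number in this assay: methoxy in place of hydrogen on that ring gives a number 69 percentage points higher from compound 3 to compound 4 (beyond the scatter). The larger 4-methoxyphenyl in place of methyl gives a number 3 percentage points lower from compound 2 to compound 4 (within the scatter), and in place of hydrogen it gives a number 40 percentage points higher from compound 1 to compound 4 (beyond the scatter), so an aryl group here can stand level with methyl. Nothing available explains this rise.

On these data alone, whether it belongs to methoxy alone stays open. An ethoxy, a hydroxy or an amine on the same ring carbon would test this.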